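Hexyl on the aromatic ring of compound 1

This account rests on a few compounds, and the source may have more. Where it says the series, first, only, none or still open, it means among the compounds named here.

Measured in a functional assay on PC-9 cells (Homo sapiens) for cytotoxicity; on this read-out lower numbers stand for stronger inhibition and higher numbers for weaker inhibition:
- compound 1 `C[C@H]1C[C@H]1C1=N[C@H](/C=C\CCc2ccccc2)CS1` gives 30.1 ug/mL
- compound 2 `CCCCCCCc1cccc(CC/C=C\[C@@H]2CSC([C@@H]3C[C@@H]3C)=N2)c1` gives 35.5 ug/mL

Not yet measured:
- compound 3 `CCCCCCc1ccc(CC/C=C\[C@@H]2CSC([C@@H]3C[C@@H]3C)=N2)cc1`

Within the data shown here, only two compounds have been measured so far, and they lie within the scatter of each other, so compound 1 does not stand apart from compound 2 in this assay. Compound 3 differs from compound 1 by a single change: hexyl in place of hydrogen on an aromatic carbon. In words, this is hexyl in place of hydrogen on an aromatic carbon, para to a large group.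

Among the measured compounds shown here, one measured step bears on this change, heptyl in place of hydrogen on an aromatic carbon: a 1.2-fold higher number from compound 1 to compound 2 (0.07 log units; within the scatter). This step is small and stays within the scatter. For the measured compounds named here, it is also the only evidence, and no measured compound carries a chain para to a large group, so the estimate needs a wide range. Going by the values given here, with only that step from compound 2 as a guide, no change beyond the scatter is expected in this assay. The expected step is a 1.1-fold higher number from compound 1 to compound 3 (0.03 log units; within the scatter). For compound 3 the estimated value is 32 ug/mL, with an expected range from 15 ug/mL to 62 ug/mL.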

Compound 3, half-maximal inhibitory concentration: 50.2 ug/mL
For compound 3 the middle estimate is 1.6-fold (0.20 log units) below the measured one, within the range that was stated.
By their numbers in this assay, from the lowest: compounds 1, 2 and 3 (each within the scatter of the next).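

In this assay the step is a 1.7-fold higher number from compound 1 to compound 3 (0.22 log units; within the scatter) for hexyl in place of hydrogen on an aromatic carbon, para to a large group. The position para to a large group on the six-membered aromatic ring thus takes a chain of 6 heavy atoms with no step beyond the scatter, a point not shown by compound 1 or compound 2, neither of which carries a chain there. No measurement in hand bears on what lies behind this result.

Compound 2 and compound 3 differ in both chain and place, so the compounds shown do not separate the effect of chain length from that of ring position, and the series still contains no change that clearly moves the number beyond the scatter. Open questions at the position para to a large group are how a longer chain such as octyl would read in this assay and whether a hexyl chain ending in an amine or a carboxylic acid would read differently from the plain hexyl of compound 3.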